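Heteroaryl swap on the fused core, compound 3 pending

The source may hold more compounds than are shown below. What is called first, only, known or untested is meant among the compounds shown, and "the series" means these compounds.

Measured so far:
Compound 1 `Cn1ccc(-c2cccc3c2CCC3c2ncc[nH]2)n1` in a functional assay on CHO cells for agonist activity at Alpha-1B adrenergic receptor (Homo sapiens), read by FLIPR and calcium flux (on this read-out higher numbers stand for an effect only at larger amounts of compound and lower numbers for an effect already at smaller amounts), gives > 10000 nM, a limit of the assay rather than a number.
Compound 2 `CS(=O)(=O)Nc1c(Cl)ccc2c1CCCC2c1ncc[nH]1` in this assay gives > 10000 nM, likewise a limit.

Where compound 1 stands: every value shown so far in this assay is a limit, and compound 1 sits at it together with compound 2 (the limit of > 10000 nM in this assay, at which 2 of the 2 values shown sit). No ordering between the two can be read from this; the pair shows only that neither reached a measurable effect within the tested range.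

Compound 3 `Cc1oncc1-c1cccc2c1CCC2c1ncc[nH]1` is the next member to be run. It differs from compound 1 in one place: 5-methyl-1,2-oxazol-4-yl in place of 1-methyl-1H-pyrazol-3-yl on an aromatic carbon. Among the compounds with values here, no step between measured compounds in this assay is available to calibrate this kind of exchange, so the expectation rests on compound 1 alone.

Expectation for this assay: no step beyond the usual scatter, and most probably again only a limit; the implied step is expected to be a step that the limit leaves unreadable from compound 1 to compound 3. Compound 3 is accordingly estimated at 15000 nM, with a range of 3000 nM to 60000 nM.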

Compound 3, half-maximal effective concentration: > 10000 nM
Compound 3 ended at the assay's limit; the forecaster's own chance of this, stated with the estimate: 80%; the middle value does not contradict the limit.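

No step can be read from compound 1 to compound 3 in this assay, since the exchange of 1-methyl-1H-pyrazol-3-yl for 5-methyl-1,2-oxazol-4-yl joins two limits: the limit of > 10000 nM in this assay, at which 3 of the 3 values shown sit.

The compounds shown leave open whether either group, or any other on this aromatic carbon of the shared core, can give a measurable effect.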